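The source may report more compounds than this note shows. Statements on the series, on what has been measured and on what is new or still open speak of the compounds shown alone.

Measured in a physicochemical assay for solubility, read by LC-MS, in phosphate buffer, with a stated time of 24 h, at pH 7.4; on this read-out higher numbers stand for higher solubility and lower numbers for lower solubility:
Compound 1 `Cc1nccn1-c1cnc(NCc2c(F)ccc3c2CCO3)c2cn[nH]c(=O)c12`: 7000 nM
Compound 2 `Cn1nccc1-c1cnc(NCc2c(F)ccc3c2CCO3)c2cn[nH]c(=O)c12`: 2000 nM
Compound 3 `Cc1nc(CN(C)C)ccc1-c1cnc(NCc2c(F)ccc3c2CCO3)c2cn[nH]c(=O)c12`: > 1000000 nM

Compound 3 gives > 1000000 nM, which is a limit and not a number. The two measured steps that lead to it are large: an at least 140-fold higher number from compound 1 to compound 3 (2.15 log units; beyond the scatter) and an at least 500-fold higher number from compound 2 to compound 3 (2.69 log units; beyond the scatter). The step between the other two compounds, each with a five-membered aromatic ring at the same place, is only modest: a 3.5-fold lower number from compound 1 to compound 2 (0.54 log units; beyond the scatter).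

Compound 4 `CNC(=O)c1ncc(-c2cnc(NCc3c(F)ccc4c3CCO4)c3cn[nH]c(=O)c23)n1C` has not been measured yet. In it, 1-methyl-2-(methylcarbamoyl)-1H-imidazol-5-yl takes the place of 6-((dimethylamino)methyl)-2-methylpyridin-3-yl on an aromatic carbon (1-methyl-2-(methylcarbamoyl)-1H-imidazol-5-yl in place of 6-((dimethylamino)methyl)-2-methylpyridin-3-yl on an aromatic carbon). The group that leaves occurs only in compound 3, and the group that enters has a five-membered aromatic ring, as do the groups in compound 1 and compound 2. Compound 4 is therefore expected to fall back towards those two, which would largely reverse an at least 140-fold higher number from compound 1 to compound 3 (2.15 log units; beyond the scatter) and an at least 500-fold higher number from compound 2 to compound 3 (2.69 log units; beyond the scatter). A large downward change is expected, estimated as an at least 100-fold lower number from compound 3 to compound 4 (2.00 log units; beyond the scatter). Among the compounds with values here, no measured compound carries the methylcarbamoyl group, so the range is kept wide. The expected value for compound 4 is 10000 nM, with an estimated range from 2000 nM to 60000 nM.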

Compound 4, solubility: 5000 nM
Compound 4: middle estimate off by 2.0-fold (0.30 log units), on the high side; the range from low to high includes it.
By their numbers in this assay, from the lowest: compound 2; then compounds 4 and 1 (each within the scatter of the next). At a limit, above all of these: compound 3.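

In this assay, the change at this position gives an at least 200-fold lower number from compound 3 to compound 4 (2.30 log units; beyond the scatter), which places a third group with a five-membered aromatic ring far from the pyridine-bearing compound. Within the data shown here, the methylcarbamoyl group on that ring, which no earlier compound carried, moves the number only a little: the comparison with the 1-methyl-1H-pyrazol-5-yl group gives a 2.5-fold higher number from compound 2 to compound 4 (0.40 log units; beyond the scatter), and the comparison with the 2-methyl-1H-imidazol-1-yl group gives a 1.4-fold lower number from compound 1 to compound 4 (0.15 log units; within the scatter). Compound 3 is recorded at a limit and not as a number, so its step shows only a minimum size: the limit of > 1000000 nM in this assay, at which 1 of the 4 values shown sits.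

The group that leaves differs from the five-membered groups in both its six-membered aromatic ring and its dimethylaminomethyl chain, and the compounds shown do not separate these two features. A plain 2-methylpyridin-3-yl group, without the chain, or a 1-methyl-1H-imidazol-5-yl group carrying a dimethylaminomethyl chain in place of the methylcarbamoyl, would be needed to tell which feature goes with the large step.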